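Trimming the amide substituent from compound 3 to compound 4

The compounds below may be only part of what the source reports. "The series", "measured", "known", "first", "only" and "open" are said of these compounds alone.

The series shares one core carrying an aminoethylamino chain and a piperazine whose far nitrogen bears a varying group. Compound 1 `NCCNc1cc(N2CCN(S(=O)(=O)c3ccccc3)CC2)nc2ccccc12` carries a phenylsulfonyl there, and in an ADME assay on HEp-2 cells (Homo sapiens) for cytotoxicity, read by CCK-8 assay, with a stated time of 6 days (on this read-out lower numbers stand for higher toxicity in this test and higher numbers for lower toxicity in this test), compound 1 gives 20500 nM. Compound 2 `NCCNc1cc(N2CCN(c3cccc(Cl)c3)CC2)nc2ccccc12` carries a 3-chlorophenyl instead, and in this assay compound 2 gives 6400 nM; the step of a 3.2-fold lower number from compound 1 to compound 2 (0.51 log units; beyond the scatter) goes toward higher toxicity. Compound 3 `NCCNc1cc(N2CCN(C(=O)C3(c4ccccc4)CCC3)CC2)nc2ccccc12` carries an amide with a 1-phenylcyclobutyl group. Going by these compounds, for compound 3 this assay reports only a limit, > 100000 nM, so its true number is unknown, and this is the limit of > 100000 nM in this assay, at which 1 of the 3 values shown sits.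

Compound 4 `CC(C)CC(=O)N1CCN(c2cc(NCCN)c3ccccc3n2)CC1` differs from compound 3 by isobutyl in place of 1-phenylcyclobutyl on a carbonyl carbon. Among the compounds with values here, no measured step touches this position, since the only measured step concerns the amine nitrogen, not the carbonyl carbon. The expectation for compound 4 in this assay is therefore 80000 nM, from 30000 nM to 200000 nM, meaning an estimated step of an at least 1.2-fold lower number from compound 3 to compound 4 (0.09 log units; that floor lies within the scatter) that may again end at a limit.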

Compound 4, half-maximal cytotoxic concentration: > 100000 nM
Compound 4 ended at the assay's limit; the forecaster's own chance of this, stated with the estimate: 50%; at least 1.2-fold (0.09 log units) between middle value and limit.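

The ring and the bulk of 1-phenylcyclobutyl are not needed to keep an amide at the top of the range, since compound 4, with an open-chain isobutyl on the same carbonyl carbon, also reaches a limit, as compound 3 does: the limit of > 100000 nM in this assay, at which 2 of the 4 values shown sit.

The step between these two compounds cannot be read, as both values are limits. The new compound does give a firmer comparison on the amine nitrogen in a ring, where isobutylcarbonyl produces an at least 15-fold higher number from compound 2 to compound 4 (1.19 log units; beyond the scatter) and an at least 4.8-fold higher number from compound 1 to compound 4 (0.68 log units; beyond the scatter) in this assay, both toward lower toxicity.

Going by these compounds, how far past the limit either amide lies remains unknown. On these data alone, it also remains open whether an amine or a carboxylic acid on that carbonyl carbon would stay at the limit or bring the number down.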